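Hydroxychalcones with a trifluoromethoxy group: four positional isomers

The compounds below may be only part of what the source reports. "The series", "measured", "known", "first", "only" and "open" are said of these compounds alone.

Measured compounds:
Compound 1, `O=C(/C=C/c1cccc(OC(F)(F)F)c1)c1cccc(O)c1`, a functional assay on RAW264.7 cells (Mus musculus) for inhibition, read by fluorescence, with stated times of 1 h, 24 h and 30 min; on this read-out higher numbers stand for weaker inhibition and lower numbers for stronger inhibition: > 10000 nM
Compound 2, `O=C(/C=C/c1cccc(OC(F)(F)F)c1)c1ccc(O)cc1`, this assay: > 10000 nM
Compound 3, `O=C(/C=C/c1ccc(OC(F)(F)F)cc1)c1cccc(O)c1`, this assay: > 10000 nM

Compound 1 gives only a limit in this assay, > 10000 nM. Compound 2 likewise gives only a limit, > 10000 nM. Compound 3 also reaches only a limit, > 10000 nM. The change from compound 1 to compound 2 is 4-hydroxyphenyl in place of 3-hydroxyphenyl on a carbonyl carbon, and its step is a step that the two limits leave unreadable from compound 1 to compound 2. The difference between the core of compound 1 and the core of compound 3 is not broken down here. Compound 4, `O=C(/C=C/c1ccc(OC(F)(F)F)cc1)c1ccc(O)cc1`, is not yet measured; it differs from compound 3 by 4-hydroxyphenyl in place of 3-hydroxyphenyl on a carbonyl carbon, the same change at the same place. Because (the limit of > 10000 nM in this assay, at which 3 of the 3 values shown sit), compound 4 is expected to sit at that limit too, with an expected step that the limit leaves unreadable from compound 3 to compound 4. The estimate for compound 4 is 20000 nM, between 8000 nM and 60000 nM.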

Compound 4, half-maximal inhibitory concentration: > 10000 nM
Compound 4 ended at the assay's limit; the forecaster's own chance of this, stated with the estimate: 85%; the middle value is on the limit's open side.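

Compound 3 and compound 4 both give only a limit, so no step can be read between them. The compounds shown leave open how strongly any of the four inhibits in this assay, and whether 4-hydroxyphenyl in place of 3-hydroxyphenyl changes that at all.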